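The source may report more compounds than this note shows. Statements on the series, on what has been measured and on what is new or still open speak of the compounds shown alone.

Measured so far:
Compound 1, `CCCn1ccc2cc(NCc3cccnc3)cc(Cl)c2c1=O`, gives 82% in a functional assay on CHO cells for agonist activity at metabotropic glutamate receptor 2 (Homo sapiens), read by GTPgammaS binding; a lower number here means a smaller maximal response, a higher number a larger maximal response.
Compound 2, `CCCn1ccc2cc(OCCc3cccnc3)cc(Cl)c2c1=O`, gives 47% in this assay.
Compound 3, `CCCn1ccc2cc(-c3ccc(Oc4ccccc4)cc3)cc(Cl)c2c1=O`, gives 88% in this assay.

Of these three, compound 3 has the highest number, yet its distance from compound 1 lies within the usual scatter of such measurements, so the two cannot be told apart on this basis. Only compound 2 stands clearly apart, well beyond the scatter and lower than compound 3.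

The next compound, compound 4, `CCCn1ccc2cc(-c3ccc(OCc4ccc(Cl)nc4)cc3)cc(Cl)c2c1=O`, differs from compound 3 in one spot: (6-chloropyridin-3-yl)methyl in place of phenyl on an oxygen on an aromatic ring. Cut one bond further out, the same change reads phenoxy to (6-chloropyridin-3-yl)methoxy. Going by the values given here, no pair of measured compounds shows exactly this change, so the step must be guessed from the three values alone. A small step is expected, downward if anything, as a number 10 percentage points lower from compound 3 to compound 4 (within the scatter). Compound 4 is estimated to reach about 78% in this assay, in the range 55% to 100%.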

Compound 4, largest response reached (Emax), in percent of the reference or control that the assay uses: 81%
For compound 4 the middle estimate is 3 percentage points below the measured one; low and high end bracket the measured number.
By their numbers in this assay, from the lowest: compound 2; then compounds 4, 1 and 3 (each within the scatter of the next).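

Replacing phenoxy with (6-chloropyridin-3-yl)methoxy gives a number 7 percentage points lower from compound 3 to compound 4 (within the scatter) in this assay, so the maximal response of the two compounds cannot be told apart. Going by these compounds alone, this is the first pair that differs in one place, and it shows that this spot on the oxygen can carry the larger group, with 8 heavy atoms instead of 6 and one hydrogen-bond acceptor instead of none, without a measurable shift in this read-out. No measured evidence is available to explain this result.

From the compounds shown here alone, the change brings in a methyl link, a ring nitrogen and a chlorine together, so the effect of each alone remains unknown. Going by these compounds, it also remains open whether a longer chain on the oxygen, or an amine or a carboxylic acid in place of the chloropyridine ring, would keep the response.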